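This account rests on a few compounds, and the source may have more. Where it says the series, first, only, none or still open, it means among the compounds named here.

Measured compounds:
- Compound 1 `CCN(CC)c1cc2[nH]c(C3CCCCC3)nc2cc1NC(=O)c1ccc(OC(F)(F)F)cc1`: in an ADME assay on Vero cells (Chlorocebus sabaeus) for cytotoxicity, read by resazurin assay, with a stated time of 3 days (on this read-out higher numbers stand for weaker inhibition and lower numbers for stronger inhibition), compound 1 gives > 100 ug/mL, which is a limit of the assay.
- Compound 2 `CCCC(C)OC(=O)Nc1cc2nc(C3CCCCC3)[nH]c2cc1N(CC)CC`: in this assay compound 2 gives > 100 ug/mL, again a limit and not a number.

Compound 2 thus stands at the upper limit of this assay, and every value shown in the series sits there too (the limit of > 100 ug/mL in this assay, at which 2 of the 2 values shown sit). Among the measured compounds shown here, the only measured step, a step that the two limits leave unreadable from compound 1 to compound 2, is unreadable in size, since both ends are limits.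

Compound 3 `C=Cc1cccc(C(=O)Nc2cc3nc(C4CCCCC4)[nH]c3cc2N(CC)CC)c1` differs from compound 2 by 3-vinylphenyl in place of 1-methylbutoxy on a carbonyl carbon. For the measured compounds named here, no measured step bears on this change with a readable size; the one step available, from an aromatic carbonyl substituent to a carbamate and back toward an aromatic one, showed nothing beyond the limit at either end. The expectation for compound 3 in this assay is therefore no step beyond the scatter, a step that the limit leaves unreadable from compound 2 to compound 3, with the value most likely again reported only as a limit. Compound 3 is estimated at 150 ug/mL, within 70 ug/mL to 400 ug/mL.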

Compound 3, half-maximal inhibitory concentration: > 100 ug/mL
Compound 3: no number, only a limit (the forecaster's own chance of this, stated with the estimate: 80%); the middle value does not contradict the limit.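

In this assay compound 3 gives > 100 ug/mL, a limit and not a number, so the steps to it from compound 1 and from compound 2 cannot be read. The compounds shown leave open whether any change on the carbonyl carbon alters this read-out at all: the limit of > 100 ug/mL in this assay, at which 3 of the 3 values shown sit.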